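Bromo for methyl on the shared core

This account rests on a few compounds, and the source may have more. Where it says the series, first, only, none or still open, it means among the compounds named here.

Measured compounds:
compound 1, `Cc1cccc2c1nc(-c1c(F)cccc1F)n2Cc1c(F)cccc1F`: > 100 uM
compound 2, `COC(=O)c1cccc2c1nc(-c1c(F)cccc1F)n2Cc1c(F)cccc1F`: 57.7 uM

In a toxicity assay on CCRF-CEM cells (Homo sapiens) for cytotoxicity (on this read-out higher numbers stand for lower toxicity in this test and lower numbers for higher toxicity in this test), compound 1 reaches only a limit of the assay, > 100 uM. Compound 2 gives a numerical value, 57.7 uM. For the measured compounds named here, the single measured step is an at least 1.7-fold lower number from compound 1 to compound 2 (0.23 log units; that floor lies within the scatter), a change of methoxycarbonyl in place of methyl on an aromatic carbon; its floor does not clear the scatter, so it says little about direction. Compound 1 sits at the limit of > 100 uM in this assay, at which 1 of the 2 values shown sits, so its own position is known only as that limit.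

Compound 3, `Fc1cccc(F)c1Cn1c(-c2c(F)cccc2F)nc2c(Br)cccc21`, differs from compound 1 in one place: bromo in place of methyl on an aromatic carbon. Going by the values given here, no measured step introduces a bromo group, and the only step from compound 1 concerns a different substituent, so nothing measured bears directly on this change.

Among the compounds with values here, with no step to lean on, compound 3 is expected to stay near the limit reached by compound 1, with the step of a number no higher from compound 1 to compound 3 (the limit leaves the size open) understood as an estimate rather than a measured shift. Compound 3 is estimated at 100 uM, in a range from 40 uM to 250 uM.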

Compound 3, half-maximal toxic concentration: 24.5 uM
Compound 3: the middle estimate sits 4.1-fold (0.61 log units) above what was measured; measured number below the stated range.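

Bromo in place of methyl, on an aromatic carbon ortho to a fused ring and meta to a fused ring, gives an at least 4.0-fold lower number from compound 1 to compound 3 (0.61 log units; beyond the scatter) in this assay, the first step at this place that clears the scatter, whereas the floor of the step to methoxycarbonyl did not. As far as these compounds go, the full size of that step stays open, since compound 1 sits at a limit of the assay: the limit of > 100 uM in this assay, at which 1 of the 3 values shown sits. Bromo in place of methoxycarbonyl gives a 2.4-fold lower number from compound 2 to compound 3 (0.37 log units; beyond the scatter), so this place also separates these two groups by more than the scatter, and compound 3 carries the lowest number of the three compounds in this test.

From the compounds shown here alone, whether the lower number is particular to bromo remains open, as does what chloro, an amine or a carboxylic acid would give on the same aromatic carbon. Also open is whether the change from methyl to bromo keeps its direction and size when other groups stand elsewhere on the shared core, which the three compounds shown cannot settle.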